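Swapping an Imidazolylethoxy Tail for Ethyl

The source may hold more compounds than are shown below. What is called first, only, known or untested is meant among the compounds shown, and "the series" means these compounds.

Compound 1, `CCc1cccc(Nc2nccc(-c3ccccn3)n2)c1`: 1400 nM
Compound 2, `c1cc(Nc2nccc(-c3ccco3)n2)cc(OCCn2ccnc2)c1`: 200 nM

In a functional assay for inhibition, with Homo sapiens as the target (a higher number here means a weaker inhibitor, a lower number a stronger inhibitor), compound 1 gives 1400 nM, while compound 2 gives 200 nM, the lower of the two numbers by a margin beyond the scatter. Compound 3, `CCc1cccc(Nc2nccc(-c3ccco3)n2)c1`, differs from compound 2 by ethyl in place of 2-(1H-imidazol-1-yl)ethoxy on an aromatic carbon. For the measured compounds named here, no measured pair differs in exactly this way, so the size of the step is uncertain. Because compound 1 carries the same ethyl group and gives 1400 nM, a weakening is expected. Compound 3 is expected to give 700 nM, with a range from 200 nM to 2500 nM. The expected step is a 3.5-fold higher number from compound 2 to compound 3 (0.54 log units; beyond the scatter).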

Compound 3, half-maximal inhibitory concentration: 9700 nM
For compound 3 the middle estimate is 14-fold (1.14 log units) below the measured one, outside the stated range (above it).
By their numbers in this assay, from the lowest: compound 2; then compound 1; then compound 3.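

For the compounds shown here, on this aromatic carbon, the 2-(1H-imidazol-1-yl)ethoxy group matters far more than the earlier compounds could show: in this assay ethyl in its place gives a 49-fold higher number from compound 2 to compound 3 (1.69 log units; beyond the scatter), the large step here. The other position also counts, since furan-2-yl in place of pyridin-2-yl gives a 6.9-fold higher number from compound 1 to compound 3 (0.84 log units; beyond the scatter) when ethyl is present. No available evidence explains either step.

On these data alone, whether the potency depends on the imidazole ring, the oxygen or the chain's length remains open. A methoxy group or a 2-aminoethoxy chain at this position could help separate these, and the tail's effect alongside pyridin-2-yl is also unknown.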